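A Cyanobenzyl Swap Assessed for Cytotoxicity

The compounds below may be only part of what the source reports. "The series", "measured", "known", "first", "only" and "open" are said of these compounds alone.

Compound 1 `COC(=O)c1ccc(NCc2cncn2Cc2ccccc2C)cc1-c1ccccc1` carries a 2-methylbenzyl group on the shared core. Among the measured compounds shown here, in a toxicity assay on NIH3T3 cells (Mus musculus) for cytotoxicity, read by resazurin assay (on this read-out higher numbers stand for an effect only at larger amounts of compound and lower numbers for an effect already at smaller amounts), compound 1 gives 10000 nM, the only actual number among the values shown. Compound 2 `c1ccc(-c2ccc(Cn3cncc3CNc3ccc(-c4noc5ccccc45)c(-c4ccccc4)c3)cc2)cc1` was tested in the same setting, and in this assay compound 2 reaches only the assay limit of > 10000 nM. For the measured compounds named here, this is where the limit of > 10000 nM in this assay, at which 1 of the 2 values shown sits, comes in, so compound 1 stands as the single measured number beside one limit. Compound 3 `COC(=O)c1ccc(NCc2cncn2Cc2cccc(C#N)c2)cc1-c1ccccc1` has not yet been measured; it differs from compound 1 by 3-cyanophenyl in place of 2-methylphenyl on a saturated chain carbon bound to an aromatic nitrogen. Going by the values given here, no step between two measured compounds exists to guide this change. The step of no change at the digits printed from compound 1 to compound 3 (within the scatter) is expected to stay within the usual scatter, in no particular direction. Compound 3 is therefore estimated at 10000 nM, with a range from 4000 nM to 25000 nM, and it may well end at the assay limit rather than a number.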

Compound 3, half-maximal effective concentration: > 10000 nM
Compound 3 ended at the assay's limit; the forecaster's own chance of this, stated with the estimate: 50%; the middle value sits exactly at the limit.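

In this assay, among the compounds shown here, the swap of 2-methylbenzyl to 3-cyanobenzyl gives the first step at this place, on a saturated chain carbon bound to an aromatic nitrogen, and it reads as a number no lower from compound 1 to compound 3 (the limit leaves the size open). Compound 3 stands at a limit of the assay and not at a number, so the size of this step cannot be read, but the change to 3-cyanophenyl, with its nitrile, does not move the read-out towards an effect at smaller amounts. The values now gather at the top of the range: the limit of > 10000 nM in this assay, at which 2 of the 3 values shown sit.

The compounds shown leave open how far compound 3 lies from compound 1, or whether the two differ at all. They also leave open whether a 3-aminobenzyl or a 3-carboxybenzyl group in this place would bring an effect at smaller amounts.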